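The compounds below may be only part of what the source reports. "The series", "measured", "known", "first", "only" and "open" are said of these compounds alone.

Going by the values given here, in a functional assay on M14 cells (Homo sapiens) for inhibition, read by sulforhodamine B assay, with a stated time of 48 h (on this read-out higher numbers stand for weaker inhibition of growth and lower numbers for stronger inhibition of growth), compound 1 `O=C(NNC(=O)c1ccc2[nH]c(-c3ccc([N+](=O)[O-])o3)nc2c1)c1ccccc1` gives 15.6 ug/mL and holds the lowest of the three numbers so far, against compound 2 `COc1cc(C(=O)NNC(=O)c2ccc3[nH]c(-c4ccc([N+](=O)[O-])s4)nc3c2)cc(OC)c1OC` at 62.5 ug/mL and compound 3 `O=C(O)c1ccc2[nH]c(-c3ccc([N+](=O)[O-])o3)nc2c1` at 250 ug/mL on the same read-out; both gaps lie beyond the scatter. Compound 4 `COc1ccc(C(=O)NNC(=O)c2ccc3[nH]c(-c4ccc([N+](=O)[O-])o4)nc3c2)cc1OC` keeps the core of compound 1 and carries 3,4-dimethoxyphenyl in place of phenyl on a carbonyl carbon. Among the compounds with values here, no step in a single place has been measured yet. Within the data shown here, compound 2 is the only measured compound with methoxy groups, and at 62.5 ug/mL it stands higher than compound 1, though it differs elsewhere too. The expected size in this assay is a modest rise toward weaker inhibition of growth, estimated as a 2.0-fold higher number from compound 1 to compound 4 (0.30 log units; within the scatter) in this series. For compound 4 the estimated value is 31 ug/mL with an expected range of 12 ug/mL to 85 ug/mL in repeat measurements.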

Compound 4, concentration for 50% growth inhibition: 15.6 ug/mL
Beside the measured number, compound 4's estimate is 2.0-fold (0.30 log units) above it, and the stated range covers the measured number.
By their numbers in this assay, from the lowest: compounds 1 and 4 (each within the scatter of the next); then compound 2; then compound 3.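

In this assay, going by these compounds alone, the first single-place step reads no change at the digits printed from compound 1 to compound 4 (within the scatter), with 3,4-dimethoxyphenyl in place of phenyl on a carbonyl carbon. This position therefore accepts the larger 3,4-dimethoxyphenyl group without a step beyond the scatter. No measurement here offers an explanation for this result.

On these data alone, whether an amine or a carboxylic acid on the phenyl ring would read the same remains open. So does the outcome of replacing that ring with a longer chain.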